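Adding a Chloro Group to a Pyrrolidine-Bearing Amide

This account rests on a few compounds, and the source may have more. Where it says the series, first, only, none or still open, it means among the compounds named here.

Compound 3 `COc1cc2c(Oc3ccc(NC(=O)c4cc(-c5ccccc5)nc5ccc(F)cc45)cc3F)ccnc2cc1OCCCN1CCCC1` gives 110 nM in a functional assay on MKN-45 cells (Homo sapiens) for cytotoxicity, read by MTT assay, with a stated time of 72 h (on this read-out lower numbers stand for stronger inhibition and higher numbers for weaker inhibition), the highest of the three numbers measured. Compound 1 `COc1cc2c(Oc3ccc(NC(=O)c4cc(-c5ccccc5)nc5ccc(F)cc45)cc3F)ccnc2cc1OCCCN1CCCCC1` gives 30 nM, and compound 2 `COc1cc2c(Oc3ccc(NC(=O)c4cc(-c5cccc(Cl)c5)nc5ccc(F)cc45)cc3F)ccnc2cc1OCCCN1CCC(C)CC1` gives 10 nM. Going by the values given here, the one single-change step known here, from compound 1 to compound 3, was a 3.7-fold higher number from compound 1 to compound 3 (0.56 log units; beyond the scatter). Compound 4 `COc1cc2c(Oc3ccc(NC(=O)c4cc(-c5cccc(Cl)c5)nc5ccc(F)cc45)cc3F)ccnc2cc1OCCCN1CCCC1` differs from compound 3 by chloro in place of hydrogen on an aromatic carbon. Among the compounds with values here, no measured pair differs by this change alone: compound 2 carries the chloro group but also another change elsewhere, so its lower number cannot be credited to the chloro group by itself. A modest lowering is therefore expected, on weak support. Compound 4 is estimated at 60 nM, within a range from 25 nM to 150 nM, an expected step of a 1.8-fold lower number from compound 3 to compound 4 (0.26 log units; within the scatter).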

Compound 4, half-maximal inhibitory concentration: 67 nM
Compound 4: middle estimate off by 1.1-fold (0.05 log units), on the low side; measured number inside the range.
By their numbers in this assay, from the lowest: compound 2; then compound 1; then compounds 4 and 3 (each within the scatter of the next).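

Chloro in place of hydrogen on this aromatic carbon, tested alone for the first time in this assay, gives a 1.6-fold lower number from compound 3 to compound 4 (0.22 log units; within the scatter), so this single change cannot be told apart from repeat-measurement scatter. With the 3-chlorophenyl group held constant, the chain-end amine matters more clearly, with pyrrolidin-1-yl in place of 4-methylpiperidin-1-yl giving a 6.7-fold higher number from compound 2 to compound 4 (0.83 log units; beyond the scatter). Nothing here gives a measured reason for either step.

Still open, as far as these compounds go, is whether a methoxy or amino group on the same aromatic carbon would give a step beyond the scatter. Also open, from the compounds shown here alone, is how a morpholin-4-yl group at the chain end would compare.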